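Compound 3 to compound 4: methoxy gives way to chloro

This account rests on a few compounds, and the source may have more. Where it says the series, first, only, none or still open, it means among the compounds named here.

Values from a functional assay on HCT-116 cells (Homo sapiens) for inhibition, read by MTT assay, with a stated time of 48 h (on this read-out higher numbers stand for weaker inhibition and lower numbers for stronger inhibition), follow, each of them a limit and not a number:
- Compound 1 `COc1cc(-c2nnc(SCc3ccc(F)cc3)n2-c2ccc(N(C)C)cc2)cc(OC)c1OC` gives > 60000 nM (a limit)
- Compound 2 `CCOC(=O)CSc1nnc(-c2cc(OC)c(OC)c(OC)c2)n1-c1ccc(N(C)C)cc1` gives > 60000 nM (a limit)
- Compound 3 `COc1ccc(NC(=O)CSc2nnc(-c3cc(OC)c(OC)c(OC)c3)n2-c2ccc(N(C)C)cc2)cc1` gives > 60000 nM (a limit)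

Compound 3 stands only at a limit, the same one its two companions reach (the limit of > 60000 nM in this assay, at which 3 of the 3 values shown sit). Compound 4 `COc1cc(-c2nnc(SCC(=O)Nc3ccc(Cl)cc3)n2-c2ccc(N(C)C)cc2)cc(OC)c1OC` differs from it in one place, with chloro in place of methoxy on an aromatic carbon. The measured steps fix no size (a step that the two limits leave unreadable from compound 1 to compound 3 and a step that the two limits leave unreadable from compound 2 to compound 3), and neither of them touches this aromatic group. Since compound 3 gives > 60000 nM (a limit), a result close to that limit is expected for compound 4 too. The expected change is an at least 1.3-fold lower number from compound 3 to compound 4 (0.12 log units; that floor lies within the scatter) (an estimate, with its direction uncertain). For compound 4 the estimate is 45000 nM (expected range 10000 nM to 90000 nM).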

Compound 4, half-maximal inhibitory concentration: 39300 nM
Beside the measured number, compound 4's estimate is 1.1-fold (0.06 log units) above it, within the range that was stated.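

In this assay chloro in place of methoxy on this aromatic carbon gives an at least 1.5-fold lower number from compound 3 to compound 4 (0.18 log units; that floor lies within the scatter) and so yields a number, though the step is only a floor within the scatter. The steps from the other two compounds read alike: an at least 1.5-fold lower number from compound 2 to compound 4 (0.18 log units; that floor lies within the scatter) and an at least 1.5-fold lower number from compound 1 to compound 4 (0.18 log units; that floor lies within the scatter) are floors of the same kind. Compound 4 alone leaves the limit that the others share: the limit of > 60000 nM in this assay, at which 3 of the 4 values shown sit.

The steps among compounds 1, 2 and 3 cannot be read. From the compounds shown here alone, whether bromo, trifluoromethyl or an amine on this aromatic carbon would move the number further remains open.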